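The source may hold more compounds than are shown below. What is called first, only, known or untested is meant among the compounds shown, and "the series" means these compounds.

Measured compounds and their values:

Compound 1, `Cc1ccc(C)c(-n2nncc2CN2C(=O)C3(C(C#N)=C(N)Oc4c3c3nc5ccccc5nc3c3ccccc43)c3ccccc32)c1`, in an ADME assay on L02 cells (Homo sapiens) for antiproliferative activity, read by MTT assay, with a stated time of 48 h (on this read-out lower numbers stand for stronger inhibition and higher numbers for weaker inhibition), gives > 50000 nM, which is a limit of the assay and not a number.
Compound 2, `Cc1ccc(-n2nncc2CN2C(=O)C3(C(C#N)=C(N)Oc4c3c3nc5ccccc5nc3c3ccccc43)c3ccccc32)cc1Cl`, in this assay gives > 50000 nM, again a limit of the assay.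
Compound 3, `Cc1ccccc1-n1nncc1CN1C(=O)C2(C(C#N)=C(N)Oc3c(N)cc4nc5ccccc5nc4c32)c2ccccc21`, in this assay gives > 50000 nM, also only a limit of the assay.

Compound 3 therefore stands nowhere in particular among the numbers shown: all three measured compounds sit at the same limit, (the limit of > 50000 nM in this assay, at which 3 of the 3 values shown sit), and no ranking among them is possible. For the measured compounds named here, the only step between two measured compounds that differ in one place, a step that the two limits leave unreadable from compound 1 to compound 2, is of a size that the two limits leave unreadable.

Compound 4, `N#CC1=C(N)Oc2c(N)cc3nc4ccccc4nc3c2C12C(=O)N(Cc1cnnn1-c1ccc(Cl)cc1Cl)c1ccccc12`, differs from compound 3 in one place: 2,4-dichlorophenyl in place of 2-methylphenyl on an aromatic nitrogen. Going by the values given here, no measured step speaks to this change, and the one step available, from one aryl group on the aromatic nitrogen to another, gave nothing readable. The expectation for compound 4 in this assay is therefore no step beyond the scatter, with the result most likely again a limit, because compound 3 gives > 50000 nM and the whole set sits at the limit of > 50000 nM in this assay, at which 3 of the 3 values shown sit.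

The estimated step that the limit leaves unreadable from compound 3 to compound 4 is expected to be essentially flat. Compound 4 is thus estimated at 60000 nM, with a range from 25000 nM to 150000 nM.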

Compound 4, half-maximal inhibitory concentration: > 50000 nM
Compound 4: only a limit was reported; the forecaster's own chance of this, stated with the estimate: 85%; the middle value is on the limit's open side.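

Compound 3 and compound 4 both sit at a limit of the assay and not at a number, so no step can be read between them. The compounds shown leave open how any one of them ranks against another, and what either aryl group on the aromatic nitrogen does, as all share one limit: the limit of > 50000 nM in this assay, at which 4 of the 4 values shown sit.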